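Chain Lengthening in a Small Antiproliferative Series

The compounds below may be only part of what the source reports. "The series", "measured", "known", "first", "only" and "open" are said of these compounds alone.

Three compounds of the series have numbers in a functional assay on MCF7 cells (Homo sapiens) for antiproliferative activity, with a stated time of 5 days; on this read-out higher numbers stand for weaker inhibition and lower numbers for stronger inhibition. Compound 1 `CCCCc1ccc2[nH]c(-c3ccc(OC)cc3)c(C=C(C#N)C#N)c2c1` gives 13 nM. Compound 2 `CCCCCc1ccc2[nH]c(-c3ccc(OC)cc3)c(C=C(C#N)C#N)c2c1` gives 76 nM; it differs from compound 1 by methyl in place of hydrogen on a saturated chain carbon, four bonds along the chain from an aromatic carbon, and that step reads a 5.8-fold higher number from compound 1 to compound 2 (0.77 log units; beyond the scatter). Compound 3 `CCCCCc1ccc2[nH]c(-c3ccc(C(F)(F)F)cc3)c(C=C(C#N)C#N)c2c1` gives 100 nM; it differs from compound 2 by trifluoromethyl in place of methoxy on an aromatic carbon, a step of a 1.3-fold higher number from compound 2 to compound 3 (0.12 log units; within the scatter). The difference between the core of compound 3 and the core of compound 1 is not broken down here; their two numbers stand apart beyond the scatter, with compound 3 carrying the highest number of the three.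

Compound 4 `CCCCCCc1ccc2[nH]c(-c3ccc(C(F)(F)F)cc3)c(C=C(C#N)C#N)c2c1` has not yet been measured in this assay. It differs from compound 3 by methyl in place of hydrogen on a saturated chain carbon, five bonds along the chain from an aromatic carbon. Within the data shown here, this is the same kind of change as the one made from compound 1 to compound 2, but not the same: there the entering methyl sits four bonds along the chain from an aromatic carbon, here five bonds along, and the cores are not identical. Among the measured compounds shown here, only that one earlier step of this kind is available to rest on, and it moved the number by a 5.8-fold higher number from compound 1 to compound 2 (0.77 log units; beyond the scatter). A weakening is therefore expected for compound 4 as well, of a size near or somewhat below the earlier one, estimated as a 2.8-fold higher number from compound 3 to compound 4 (0.45 log units; beyond the scatter). Compound 4 is expected to give about 280 nM, most likely between 100 nM and 800 nM.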

Compound 4, half-maximal inhibitory concentration: 68 nM
Compound 4: middle estimate off by 4.1-fold (0.61 log units), on the high side, outside the stated range (below it).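

In this assay, methyl in place of hydrogen on a saturated chain carbon, five bonds along the chain from an aromatic carbon, gives a 1.5-fold lower number from compound 3 to compound 4 (0.17 log units; within the scatter), so the weakening seen for this kind of change on the methoxy compounds does not recur on the trifluoromethyl compounds. One more methyl on the chain therefore cannot be carried from one core to another in this series as a fixed increment, as the two steps clearly differ: the same change on two cores in this assay, a 5.8-fold higher number (0.77 log units; beyond the scatter) from compound 1 to compound 2 and a 1.5-fold lower number (0.17 log units; within the scatter) from compound 3 to compound 4, 8.6-fold (0.93 log units) apart, beyond the scatter of two such steps This does not show which difference matters, since the two steps differ both in where the methyl enters, four bonds along the chain or five, and in whether the compounds carry methoxy or trifluoromethyl on an aromatic carbon, and with a single step on each core these two readings cannot be separated.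

Still open, going by these compounds, is whether the chain of compound 4 paired with methoxy, or the chain of compound 1 paired with trifluoromethyl, would place both chain steps on one core and so settle the matter. Also open, on these data alone, is how the series responds to a longer chain than that of compound 4, or to a chain carrying an amine or a carboxylic acid.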